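The compounds below may be only part of what the source reports. "The series", "measured", "known", "first", "only" and "open" are said of these compounds alone.

In a functional assay on SW 1116 cells (Homo sapiens) for cytotoxicity, read by MTT assay, with a stated time of 48 h (a higher number here means a weaker inhibitor, a lower number a stronger inhibitor), three hydrazones built on one shared core have been measured: compound 1 `COc1ccc(/C=N/NC(=O)CSc2nnc(-c3ccncc3)o2)cc1` gives 20300 nM, compound 2 `Cc1ccc(/C=N/NC(=O)CSc2nnc(-c3ccncc3)o2)cc1` gives 16800 nM, and compound 3 `O=C(CSc1nnc(-c2ccncc2)o1)N/N=C/c1ccccc1[N+](=O)[O-]` gives 30700 nM. Compound 3 sits at the top of this tight group, yet both gaps are small: a 1.5-fold higher number from compound 1 to compound 3 (0.18 log units; within the scatter) and a 1.8-fold higher number from compound 2 to compound 3 (0.26 log units; within the scatter), while exchanging the para substituent gave a 1.2-fold lower number from compound 1 to compound 2 (0.08 log units; within the scatter). Compound 4 `O=C(CSc1nnc(-c2ccncc2)o1)N/N=C/c1cc(Cl)cc(Cl)c1O` differs from compound 3 in that (3,5-dichloro-2-hydroxyphenyl in place of 2-nitrophenyl on a carbon with a double bond to nitrogen). The two earlier exchanges of the aryl group on the carbon with a double bond to nitrogen both stayed within the scatter, so no step beyond the scatter is expected in this assay here either. Compound 4 is therefore expected to give about 25000 nM, between 10000 nM and 60000 nM, an expected step of a 1.2-fold lower number from compound 3 to compound 4 (0.09 log units; within the scatter).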

Compound 4, half-maximal inhibitory concentration: 5030 nM
Beside the measured number, compound 4's estimate is 5.0-fold (0.70 log units) above it; measured number below the stated range.
By their numbers in this assay, from the lowest: compound 4; then compounds 2, 1 and 3 (each within the scatter of the next).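

Within the data shown here, the aryl group on the carbon with a double bond to nitrogen matters more in this assay than the earlier compounds showed: 3,5-dichloro-2-hydroxyphenyl gives steps beyond the scatter against all three, (a 6.1-fold lower number from compound 3 to compound 4 (0.79 log units; beyond the scatter)), (a 3.3-fold lower number from compound 2 to compound 4 (0.52 log units; beyond the scatter)) and (a 4.0-fold lower number from compound 1 to compound 4 (0.61 log units; beyond the scatter)). The earlier aryl exchanges had all stayed within the scatter. No measurement at hand accounts for this difference.

The hydroxyl and the chlorine atoms enter together, so the compounds shown leave open which of them carries the step. From the compounds shown here alone, how an amine or a carboxylic acid on this ring would read also remains open.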